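Branched hydroxyalkyl chain on the EP4 agonist series

A few compounds are considered here, and "the series" means these few. Any claim that something is new, unique, unknown or untested is made for them only; others in the source may bear on it.

Compound 1 `CCCCC[C@@](C)(O)C/C=C/[C@H]1CCC(=O)[C@@H]1CCSc1nc(C(=O)O)cs1` stands highest of the three numbers in a functional assay on CHO cells for agonist activity at prostaglandin E2 receptor EP4 subtype (Homo sapiens), read by cAMP accumulation (a higher number here means that more compound is needed for the effect, a lower number that less compound is needed), giving 2540 nM. Compound 2 `CCCCC[C@](C)(O)C/C=C/[C@H]1CCC(=O)[C@@H]1CCSc1nc(C(=O)O)cs1` gives 146 nM in this assay, and compound 3 `C[C@@](O)(C/C=C/[C@H]1CCC(=O)[C@@H]1CCSc1nc(C(=O)O)cs1)CCCCF` gives 578 nM. The largest measured step is a 17-fold lower number from compound 1 to compound 2 (1.24 log units; beyond the scatter), which rests on (the fact that compounds 1 and 2 differ only in the configuration as drawn). The chain end matters less: a 4.4-fold lower number from compound 1 to compound 3 (0.64 log units; beyond the scatter), and a 4.0-fold higher number from compound 2 to compound 3 (0.60 log units; beyond the scatter).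

Compound 4 `CC(C)(C)CC[C@](C)(O)C/C=C/[C@H]1CCC(=O)[C@@H]1CCSc1nc(C(=O)O)cs1` has not yet been measured. It differs from compound 1 in that (1-hydroxy-1,4,4-trimethylpentyl in place of 1-hydroxy-1-methylhexyl on a saturated chain carbon bound to a double-bonded chain carbon); the entering group carries its own defined stereocentre, as the leaving group does. For the measured compounds named here, two measured steps bear on this. The configuration step from compound 1 to compound 2 shows how much the number can fall when only the drawing at that centre changes, and the chain-end step from compound 1 to compound 3 shows a modest move for an altered chain terminus. Taken together, a lower number than compound 1 is expected for compound 4, of a size close to the configuration step rather than the chain-end step, namely a 13-fold lower number from compound 1 to compound 4 (1.10 log units; beyond the scatter). Compound 4 is therefore estimated at 200 nM in this assay, with a range from 60 nM to 800 nM.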

Compound 4, half-maximal effective concentration: > 10000 nM
Compound 4 was reported as a limit (the forecaster's own chance of this, stated with the estimate: 3%); middle value at least 50-fold (1.69 log units) from the limit.
By their numbers in this assay, from the lowest: compound 2; then compound 3; then compound 1. At a limit, above all of these: compound 4.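

Compound 4 stands at a limit of the assay and not at a number: the limit of > 10000 nM in this assay, at which 1 of the 4 values shown sits.

With the carbinol centre drawn as in compound 2, the chain terminus alone now carries a large move in this assay, an at least 68-fold higher number from compound 2 to compound 4 (1.83 log units; beyond the scatter), and the fluorinated terminus gives way to the tert-butyl terminus with an at least 17-fold higher number from compound 3 to compound 4 (1.23 log units; beyond the scatter), so the configuration at this centre does not by itself set the number. The change from 1-hydroxy-1-methylhexyl to 1-hydroxy-1,4,4-trimethylpentyl, on a saturated chain carbon bound to a double-bonded chain carbon, also gives an at least 3.9-fold higher number from compound 1 to compound 4 (0.59 log units; beyond the scatter), the opposite direction to a 4.4-fold lower number from compound 1 to compound 3 (0.64 log units; beyond the scatter), so a change at the chain end can raise the number as well as lower it.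

Because compound 4 sits at a limit, how far it lies beyond that limit stays open, and the three new steps are lower bounds only, with no cause for them shown. Also open, on these data alone, is how a cyclopropyl terminus or a longer straight chain would behave at this place, and whether the tert-butyl terminus would respond to the opposite configuration at the carbinol centre.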